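The source may hold more compounds than are shown below. What is called first, only, known or untested is meant among the compounds shown, and "the series" means these compounds.

Compound 2 `COc1ccc(NC(=S)OCCNC(=O)c2cccnc2)cc1` stands at the only number shown in an ADME assay on WI-38 cells (Homo sapiens) for cytotoxicity, read by MTT assay, with a stated time of 48 h (on this read-out lower numbers stand for stronger inhibition and higher numbers for weaker inhibition), where compound 2 gives 781000 nM. Compound 1 `O=C(NCCOC(=S)Nc1ccc(F)cc1)c1cccnc1` reaches only a limit in this assay, > 800000 nM. Among the measured compounds shown here, the single measured step, an at least 1.0-fold lower number from compound 1 to compound 2 (0.01 log units; that floor lies within the scatter), rests on the limit of > 800000 nM in this assay, at which 1 of the 2 values shown sits, and so offers no size beyond the scatter. Compound 3 `Cc1ccc(NC(=S)OCCNC(=O)c2cccnc2)cc1` differs from compound 2 by methyl in place of methoxy on an aromatic carbon. For the measured compounds named here, no measured step speaks to this change, so for compound 3 in this assay no shift beyond the scatter is expected. Compound 3 is therefore estimated at 800000 nM, between 400000 nM and 1600000 nM, an expected step of a 1.0-fold higher number from compound 2 to compound 3 (0.01 log units; within the scatter).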

Compound 3, half-maximal inhibitory concentration: > 800000 nM
Compound 3 gave a limit, no number; the forecaster's own chance of this, stated with the estimate: 50%; the middle value lies on the limit itself.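

Methyl in place of methoxy, on an aromatic carbon para to a large group, gives an at least 1.0-fold higher number from compound 2 to compound 3 (0.01 log units; that floor lies within the scatter) in this assay. Compound 1 and compound 3 each stand at a limit, and the step joining them cannot be read. Methyl thus joins fluoro at the limit, and no step at this position yet shows a size beyond the scatter: the limit of > 800000 nM in this assay, at which 2 of the 3 values shown sit.

Going by these compounds, whether an amine or a carboxylic acid at this position, or a longer chain in place of methyl, would give a clearly lower number in this assay stays open.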